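Cell Toxicity Series: Estimating Compound 4 From Compound 3

The source may hold more compounds than are shown below. What is called first, only, known or untested is meant among the compounds shown, and "the series" means these compounds.

Compound 1, `COc1cc(NC(C)CCCNC(=O)/C=C/c2ccccc2)c2ncccc2c1`: in an ADME assay on L6 cells (Rattus norvegicus) for cytotoxicity, read by resazurin assay, with a stated time of 70 h (on this read-out lower numbers stand for stronger inhibition and higher numbers for weaker inhibition), compound 1 gives 7.2 ug/mL.
Compound 2, `COc1ccc(/C=C/C(=O)NCCCC(C)Nc2cc(OC)cc3cccnc23)cc1`: compound 2 reaches only a limit of the assay, > 100 ug/mL.
Compound 3, `COc1cc(NC(C)CCCNC(=O)/C=C/c2ccc(Cl)cc2)c2ncccc2c1`: compound 3 gives 7.1 ug/mL.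

Compound 3 stands alongside compound 1 among the two numbers shown, the pair sitting within the scatter of each other, as a 1.0-fold lower number from compound 1 to compound 3 (0.01 log units; within the scatter) shows; the third value, that of compound 2, is a limit rather than a number (the limit of > 100 ug/mL in this assay, at which 1 of the 3 values shown sits).

Compound 4, `COc1cc(NC(C)CCCNC(=O)/C=C/c2ccccc2F)c2ncccc2c1`, has not yet been measured. It differs from compound 3 by 2-fluorophenyl in place of 4-chlorophenyl on a double-bonded chain carbon bound to a double-bonded chain carbon.

Among the compounds with values here, two measured steps bear on this change. Placing chloro where compound 1 carries hydrogen gave a 1.0-fold lower number from compound 1 to compound 3 (0.01 log units; within the scatter), no movement beyond the scatter. Placing methoxy in the same position instead gave an at least 13-fold higher number from compound 1 to compound 2 (1.14 log units; beyond the scatter), and the reverse exchange of that methoxy for chloro gave an at least 14-fold lower number from compound 2 to compound 3 (1.14 log units; beyond the scatter). A halogen on this aromatic ring thus left the number where the unsubstituted ring sat, while methoxy pushed it to the limit. Since compound 4 exchanges one halogen for another, a step of a 1.1-fold higher number from compound 3 to compound 4 (0.05 log units; within the scatter) is expected, within the scatter.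

Compound 4 is therefore estimated at 8 ug/mL, with a range from 3 ug/mL to 25 ug/mL.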

Compound 4, half-maximal inhibitory concentration: 1.5 ug/mL
Compound 4: middle estimate off by 5.3-fold (0.73 log units), on the high side; the whole stated range lies above it.
By their numbers in this assay, from the lowest: compound 4; then compounds 3 and 1 (each within the scatter of the next). At a limit, above all of these: compound 2.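

In this assay, a halogen on this ring no longer looks like a neutral substitution: fluoro in place of hydrogen gave a 4.8-fold lower number from compound 1 to compound 4 (0.68 log units; beyond the scatter), whereas the chloro of compound 3 had left the number within the scatter of compound 1. The direct exchange of 4-chlorophenyl for 2-fluorophenyl gave a 4.7-fold lower number from compound 3 to compound 4 (0.68 log units; beyond the scatter), so the two halogen-bearing rings do not read alike, and compound 4 now holds the lowest number of the four, with its steps to all three others printed as beyond the scatter. The exchange of 4-methoxyphenyl for 2-fluorophenyl gave an at least 66-fold lower number from compound 2 to compound 4 (1.82 log units; beyond the scatter), a step that can only be read as a minimum, as compound 2 stands at a limit and not at a number: the limit of > 100 ug/mL in this assay, at which 1 of the 4 values shown sits.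

The halogen and its place on the ring change together in this step, and the compounds shown do not tell the two apart. On these data alone, how a ring carrying an amine or a carboxylic acid would read in this assay also stays open.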